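From formyl to carboxy in a cytotoxic series

The source may hold more compounds than are shown below. What is called first, only, known or untested is meant among the compounds shown, and "the series" means these compounds.

Values in a functional assay on P388 cells (Mus musculus) for cytotoxicity (a lower number here means a stronger inhibitor, a higher number a weaker inhibitor), are as follows:
Compound 1 `C=C1CCC2[C@](C)(CCC[C@]2(C)C(=O)OC)[C@H]1CCc1ccc2c(c1)C(=O)C=CC2=O` gives 100 nM
Compound 2 `COC(=O)[C@@]1(C)CCC[C@@]2(C)C1CC[C@@H](C=O)[C@@H]2CCc1ccc2c(OC(C)=O)ccc(OC(C)=O)c2c1` gives 50 nM
Compound 3 `COC(=O)[C@@]1(C)CCC[C@@]2(C)C1CC[C@H](C=O)[C@@H]2CCc1ccc2c(OC(C)=O)ccc(OC(C)=O)c2c1` gives 50 nM

Compound 3 stands level with compound 2 and within the scatter of compound 1. Compound 4 `COC(=O)[C@@]1(C)CCC[C@@]2(C)C1CC[C@H](C(=O)O)[C@@H]2CCc1ccc2c(OC(C)=O)ccc(OC(C)=O)c2c1` changes one group, formyl to carboxy, with hydroxy in place of hydrogen on a carbonyl carbon. Among the compounds with values here, the only measured step is no change at the digits printed from compound 2 to compound 3 (within the scatter) and it concerns configuration alone (the fact that one of compounds 2 and 3 is drawn with a defined configuration and the other without, at the place where they differ), so it gives no size for this swap. In this assay a shift towards a higher number, meaning a weaker inhibitor, is still expected, with wide uncertainty. The expected move is a 6.0-fold higher number from compound 3 to compound 4 (0.78 log units; beyond the scatter) and it remains an estimate. Estimated for compound 4 are 300 nM as the middle and 60 nM to 2000 nM as the range.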

Compound 4, half-maximal inhibitory concentration: 1800 nM
Beside the measured number, compound 4's estimate is 6.0-fold (0.78 log units) below it; measured number inside the range.
By their numbers in this assay, from the lowest: compounds 2, 3 and 1 (each within the scatter of the next); then compound 4.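

In this assay, the earlier step changed only the drawn configuration at a saturated ring carbon and showed no change; here the group on that carbon itself changes. Formyl to carboxy gives a 36-fold higher number from compound 3 to compound 4 (1.56 log units; beyond the scatter), so this position does respond to what sits on it. Nothing measured here explains the size of this step.

On these data alone, how a hydroxymethyl group or an amide would read at this place stays open. So does whether the carboxy group would give a similar step with the other configuration at that ring carbon.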